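Adding a bromo group to compound 2

This account rests on a few compounds, and the source may have more. Where it says the series, first, only, none or still open, it means among the compounds named here.

Measured so far:
compound 1 `COc1cc(O)c(C(=O)/C=C/c2ccc(F)cc2)c(OC)c1`: 5400 nM
compound 2 `COc1cc(OC)c(C(=O)/C=C/c2ccccc2)c(OC)c1`: 6900 nM
compound 3 `COc1cc(O)c(C(=O)/C=C/c2ccccc2OC)c(OC)c1`: 10100 nM

In a functional assay on RL cells (Homo sapiens) for cytotoxicity, with a stated time of 48 h (on this read-out higher numbers stand for weaker inhibition and lower numbers for stronger inhibition), compound 2 gives 6900 nM. This number lies within the usual scatter of repeated measurements from both compound 1 and compound 3, so compound 2 cannot be told apart from either of them.

The unmeasured compound 4 `COc1cc(OC)c(C(=O)/C=C/c2ccc(Br)cc2)c(OC)c1` differs from compound 2 in one place: bromo in place of hydrogen on an aromatic carbon. This is bromo in place of hydrogen on an aromatic carbon, para to a large group, which turns phenyl to 4-bromophenyl.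

Among the compounds with values here, no two measured compounds differ in only one place, so the data give no direct size for a change like this. The closest guide is compound 1, which carries a fluoro group on the same ring and gives 5400 nM, within the scatter of compound 2, although those two also differ elsewhere. A step no larger than the scatter is therefore expected, with a slight lean toward stronger inhibition. The estimate amounts to an expected 1.4-fold lower number from compound 2 to compound 4 (0.14 log units; within the scatter), which stays within the scatter. The estimated value for compound 4 is 5000 nM, with an expected range of 1800 nM to 14000 nM.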

Compound 4, half-maximal inhibitory concentration: 8300 nM
Beside the measured number, compound 4's estimate is 1.7-fold (0.22 log units) below it; measured number inside the range.
By their numbers in this assay, from the lowest: compounds 1, 2, 4 and 3 (each within the scatter of the next).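

In this assay the step is a 1.2-fold higher number from compound 2 to compound 4 (0.08 log units; within the scatter) and gives the first direct one-place comparison among these compounds. Bromo in place of hydrogen on this aromatic carbon, para to a large group, therefore leaves compound 4 impossible to tell apart from compound 2 on this read-out. At this position, then, turning phenyl to 4-bromophenyl adds one heavy atom without producing a step larger than the difference expected between repeated measurements, and the compounds shown offer no measurement that could explain this result.

Going by these compounds, whether this position would stay just as unresponsive with a different kind of group, such as an amine, a carboxylic acid or a longer chain, remains open. On these data alone, it is also open whether the same bromo-for-hydrogen change would give a similarly small step on the core of compound 1, which carries a hydroxy group on its other ring, as a single comparison on one core cannot show how the change behaves on another.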